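Dimethylsulfamoyl for chloro on the aryl ring

This account rests on a few compounds, and the source may have more. Where it says the series, first, only, none or still open, it means among the compounds named here.

Measured so far:
compound 1 `CC(C)COc1ccccc1-c1ncc(C(=O)O)c(=O)[nH]1` gives 0.5 mg/kg
compound 2 `C=CCc1cccc(-c2ncc(C(=O)O)c(=O)[nH]2)c1O` gives > 0.5 mg/kg
compound 3 `CCOc1ccc(Cl)cc1-c1ncc(C(=O)O)c(=O)[nH]1` gives 0.5 mg/kg

In a functional assay on the whole organism (strain Sprague-Dawley) for inhibition, with Rattus norvegicus as the target, with a stated time of 10 min (on this read-out higher numbers stand for an effect only at larger amounts of compound and lower numbers for an effect already at smaller amounts), compound 1 gives 0.5 mg/kg. In the same assay compound 3 gives 0.5 mg/kg, level with compound 1 at the digits shown, within the scatter, so no order between the two can be read. The value of compound 2 in this assay is a limit, not a number: the limit of > 0.5 mg/kg in this assay, at which 1 of the 3 values shown sits. Within the data shown here, no pair of measured compounds differs in a single place, so no measured step is available as a guide.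

Compound 4 `CCOc1ccc(S(=O)(=O)N(C)C)cc1-c1ncc(C(=O)O)c(=O)[nH]1` is not yet measured in this assay. It differs from compound 3 by dimethylsulfamoyl in place of chloro on an aromatic carbon.

Among the measured compounds shown here, with no step of this kind on record, the expectation for compound 4 in this assay rests only on compound 3 at 0.5 mg/kg and on the size of the entering group. The step from compound 3 to compound 4 is expected to be a 2.0-fold higher number from compound 3 to compound 4 (0.30 log units; within the scatter), a modest move toward larger doses, and it may well stay within the scatter. For compound 4 the estimate in this assay is 1 mg/kg, with a range from 0.3 mg/kg to 4 mg/kg.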

Compound 4, dose for 50% inhibition: > 50 mg/kg
Compound 4 ended at the assay's limit (the forecaster's own chance of this, stated with the estimate: 35%); middle value at least 50-fold (1.69 log units) away from the limit.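

In this assay, the aromatic carbon para to an ethoxy group does not accept every group: dimethylsulfamoyl in place of chloro brings an at least 100-fold higher number from compound 3 to compound 4 (2.00 log units; beyond the scatter). Among these compounds, the value of compound 4 is a limit of the assay, not a number, so the true size of the step stays unknown beyond what is printed: the limit of > 50 mg/kg in this assay, at which 1 of the 4 values shown sits. This is the first change at a single place that can be read, and it shows that the group on this carbon alone can separate a compound active at low dose from one that shows no measured dose for half inhibition, with the rest of the structure of compound 3 kept unchanged.

As far as these compounds go, whether the step follows the number of heavy atoms or the hydrogen-bond acceptors of the entering group stays open, as dimethylsulfamoyl brings more of both than chloro, and one step cannot separate the two. Fluoro, methyl or methylsulfonyl on the same carbon, or a plain hydrogen there, would show how much of this carbon's substitution the series can carry and whether chloro itself matters.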